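The compounds below may be only part of what the source reports. "The series", "measured", "known", "first", "only" and "open" are said of these compounds alone.

Measured so far in an assay on HEK293 cells for displacement of a labelled ligand from prostaglandin D2 receptor 2 (Homo sapiens); on this read-out higher numbers stand for weaker inhibition and lower numbers for stronger inhibition:
- compound 1 `O=C(O)Cn1c(SCc2cccc(Cl)c2)nc2ccccc21`: 186 nM
- compound 2 `O=C(O)Cn1c(SCc2cc(Cl)ccc2Cl)nc2ccccc21`: 470 nM
- compound 3 `COc1ccc(Cl)cc1CSc1nc2ccccc2n1CC(=O)O`: 740 nM

Compound 3 gives the highest number of the three, but its gap to compound 2, a 1.6-fold higher number from compound 2 to compound 3 (0.20 log units; within the scatter), lies within the scatter; only against compound 1, a 4.0-fold higher number from compound 1 to compound 3 (0.60 log units; beyond the scatter), is the gap beyond it. Compound 4 `COc1ccc(C(C)O)cc1CSc1nc2ccccc2n1CC(=O)O` differs from compound 3 by 1-hydroxyethyl in place of chloro on an aromatic carbon. Among the compounds with values here, no measured step involves a 1-hydroxyethyl group; the only steps on this ring, a 2.5-fold higher number from compound 1 to compound 2 (0.40 log units; beyond the scatter) and a 4.0-fold higher number from compound 1 to compound 3 (0.60 log units; beyond the scatter), were modest rises from substitution, and a 1.6-fold higher number from compound 2 to compound 3 (0.20 log units; within the scatter) stayed within the scatter. For compound 4 in this assay a step of a 1.4-fold higher number from compound 3 to compound 4 (0.13 log units; within the scatter) is therefore expected, most likely within the scatter, with the direction uncertain. The estimate for compound 4 is 1000 nM, range 350 nM to 3000 nM.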

Compound 4, half-maximal inhibitory concentration: 2200 nM
Beside the measured number, compound 4's estimate is 2.2-fold (0.34 log units) below it; low and high end bracket the measured number.
By their numbers in this assay, from the lowest: compound 1; then compounds 2 and 3 (each within the scatter of the next); then compound 4.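

Within the data shown here, compounds 1, 2 and 3 all carry chloro at this position, para to a methoxy group in compounds 3 and 4, so this is the first change here that can be read. In this assay, replacing chloro with 1-hydroxyethyl gives a 3.0-fold higher number from compound 3 to compound 4 (0.47 log units; beyond the scatter), so this position does not accept the replacement without a measurable rise. Nothing available explains the rise.

Going by these compounds, it remains open whether the hydroxyl or the added carbons account for the step. An ethyl group, an amine or a carboxylic acid at this position would help separate these possibilities.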